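This account rests on a few compounds, and the source may have more. Where it says the series, first, only, none or still open, it means among the compounds named here.

Measured compounds:
- compound 1, `N[C@H]1CC[C@H](Nc2c(C(=O)NCc3ccc(F)cc3)nc(Br)c3cccnc23)CC1`: in a functional assay on MDA-MB-435 cells (Homo sapiens) for cytotoxicity, read by MTT assay, with a stated time of 72 h (on this read-out lower numbers stand for stronger inhibition and higher numbers for weaker inhibition), compound 1 gives 6000 nM.
- compound 2, `O=C(NCc1ccc(F)cc1)c1nc(Br)c2cccnc2c1NCc1ccccc1`: in this assay compound 2 reaches only > 20000 nM, a limit of the assay and not a number.

Among the compounds with values here, compound 1 is the only member of the pair with a measured number; the other value shown is the limit (the limit of > 20000 nM in this assay, at which 1 of the 2 values shown sits). Within the data shown here, the one measured step in this set, an at least 3.3-fold higher number from compound 1 to compound 2 (0.52 log units; beyond the scatter), concerns the substituent on the ring nitrogen and not the benzylamide end.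

Compound 3, `N[C@H]1CC[C@H](Nc2c(C(=O)NCc3ccccc3)nc(Br)c3cccnc23)CC1`, differs from compound 1 in the benzylamide portion: hydrogen in place of fluoro on an aromatic carbon. Among the measured compounds shown here, no measured step touches this position, so nothing argues for a move beyond the scatter in either direction in this assay. The step of a 1.2-fold higher number from compound 1 to compound 3 (0.07 log units; within the scatter) is therefore expected to stay within the usual scatter. Compound 3 is estimated at 7000 nM in this assay, with a range from 3000 nM to 20000 nM.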

Compound 3, half-maximal inhibitory concentration: 7000 nM
Beside the measured number, compound 3's estimate shows no gap at the digits printed, and the stated range covers the measured number.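

The benzylamide end now has a measured step in this assay: hydrogen in place of fluoro on the aromatic carbon gives a 1.2-fold higher number from compound 1 to compound 3 (0.07 log units; within the scatter). Within the data shown here, the only earlier step concerned the substituent on the ring nitrogen, so this is the first reading of the far end of the molecule, and at this position 4-fluorobenzyl and benzyl cannot be told apart in this assay. No measured property among the data shown bears on this result.

Open, on these data alone, is whether a more drastic change at this position, such as a carboxylic acid or an aminomethyl group in place of the fluoro, would move the number beyond the scatter. Equally open, as far as these compounds go, is whether a phenethyl group in place of the benzyl on the amide would do so.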